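The compounds below may be only part of what the source reports. "The series", "measured", "known", "first", "only" and "open" are said of these compounds alone.

Values from a functional assay on P388 cells (Mus musculus) for cytotoxicity (on this read-out higher numbers stand for weaker inhibition and lower numbers for stronger inhibition), as follows
- compound 1 `C[C@@H]1NC(=O)[C@@H](C)NC(=O)[C@@H]2Cc3cccc(c3)Oc3ccc(cc3)C[C@@H](C(=O)N2C)N(C)C(=O)[C@H](C)NC(=O)[C@H](Cc2ccccc2)N(C)C1=O` gives 525 nM
- compound 2 `C/C=C/CN1C(=O)[C@@H](C)NC(=O)[C@@H]2Cc3ccc(OC)c(c3)Oc3ccc(cc3)C[C@@H](C(=O)N2C)N(C)C(=O)[C@H](C)NC(=O)[C@H](Cc2ccc(OC)cc2)N(C)C(=O)[C@@H]1C` gives 9.12 nM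
- compound 3 `C=Cc1ccc(C[C@H]2C(=O)N[C@@H](C)C(=O)N(C)[C@H]3Cc4ccc(cc4)Oc4cc(ccc4OC)C[C@@H](C(=O)N[C@H](C)C(=O)N[C@@H](C)C(=O)N2C)N(C)C3=O)cc1` gives 17 nM

Compound 3 (17 nM) lies within the scatter of compound 2 and well below compound 1, so it sits among the stronger inhibitors of this small set. Compound 4 `COc1ccc(C[C@H]2C(=O)N[C@@H](C)C(=O)N(C)[C@H]3Cc4ccc(cc4)Oc4cc(ccc4OC)C[C@@H](C(=O)N[C@H](C)C(=O)N[C@@H](C)C(=O)N2C)N(C)C3=O)cc1O` carries 3-hydroxy-4-methoxyphenyl in place of 4-vinylphenyl on a saturated chain carbon bound to a saturated ring carbon. Among the measured compounds shown here, no measured pair isolates this change, so its size is uncertain. In this assay only a small shift toward weaker inhibition is expected, not beyond the scatter (a 1.8-fold higher number from compound 3 to compound 4 (0.25 log units; within the scatter)). Compound 4 is estimated at 30 nM (expected range 8 nM to 120 nM) in the next measurement.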

Compound 4, half-maximal inhibitory concentration: 214 nM
For compound 4 the middle estimate is 7.1-fold (0.85 log units) below the measured one; measured number above the stated range.
By their numbers in this assay, from the lowest: compounds 2 and 3 (each within the scatter of the next); then compound 4; then compound 1.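

At this position, on a saturated chain carbon bound to a saturated ring carbon, the choice of aryl group matters in this assay: 3-hydroxy-4-methoxyphenyl in place of 4-vinylphenyl gives a 13-fold higher number from compound 3 to compound 4 (1.10 log units; beyond the scatter) and so moves the value beyond the scatter. Among the compounds shown here, the earlier compounds held no pair isolating any change, so this is the first direct reading of this position. No evidence on hand explains the size of this step.

The change removes the vinyl group and adds hydroxy and methoxy groups together, so the compounds shown do not separate their contributions. Also open, on these data alone, is how an amine or a carboxylic acid on this phenyl ring would read.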